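From compound 2 to compound 4: working notes

The compounds below may be only part of what the source reports. "The series", "measured", "known", "first", "only" and "open" are said of these compounds alone.

Values so far in a physicochemical assay for solubility, in phosphate buffer, measured as kinetic solubility; a higher number here means a more soluble compound, a lower number a less soluble compound 
Compound 1 `CC(C)C(/C=C1\NC(=O)NC1=O)c1ccc(-c2ccc3cccc(F)c3c2)[nH]c1=O` gives 10700 nM 
Compound 2 `CC(C)C(CC1C(=O)NC(=O)N1C)c1ccc(-c2ccc3cccc(F)c3c2)[nH]c1=O` gives 33600 nM 
Compound 3 `Cc1cc(C(/C=C2\OC(=O)NC2=O)C(C)C)c(=O)[nH]c1-c1ccc2cccc(F)c2c1` gives 35700 nM 

Compound 4 `CC(C)C(c1ccc(-c2ccc3cccc(F)c3c2)[nH]c1=O)C1NC(=O)NC1=O` has no value yet in this assay and is the subject of these notes.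

Compound 2 (33600 nM) and compound 3 (35700 nM) lie within the scatter of each other at the top of the three numbers, and compound 1 (10700 nM) lies lower than compound 2 by more than the scatter. The change to compound 4 is 2,5-dioxoimidazolidin-4-yl in place of (3-methyl-2,5-dioxoimidazolidin-4-yl)methyl on a saturated chain carbon bound to an aromatic carbon and a saturated chain carbon with 2,5-dioxoimidazolidin-4-yl in place of (3-methyl-2,5-dioxoimidazolidin-4-yl)methyl on a saturated chain carbon bound to an aromatic carbon and a saturated chain carbon.

Going by the values given here, one measured step bears on this change, namely a 3.1-fold higher number from compound 1 to compound 2 (0.50 log units; beyond the scatter) and it is modest. Among the compounds with values here, in that step the (3-methyl-2,5-dioxoimidazolidin-4-yl)methyl group came in, and here it leaves, although the group entering now differs from the one carried by compound 1. Within the data shown here, no measured compound carries the entering group, so this precedent is only partial. A modest move to a lower number is therefore expected in this assay on this single step. The expected step is a 2.2-fold lower number from compound 2 to compound 4 (0.35 log units; beyond the scatter) and it remains an estimate. Compound 4 is estimated at 15000 nM with an expected range from 6000 nM to 38000 nM in this measurement.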

Compound 4, solubility: 10600 nM
Estimate against measurement, compound 4: 1.4-fold (0.15 log units) above; the measured number falls inside the stated range.
By their numbers in this assay, from the lowest: compounds 4 and 1 (each within the scatter of the next); then compounds 2 and 3 (each within the scatter of the next).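

In this assay, taking the (3-methyl-2,5-dioxoimidazolidin-4-yl)methyl group off the saturated chain carbon and putting 2,5-dioxoimidazolidin-4-yl there gives a 3.2-fold lower number from compound 2 to compound 4 (0.50 log units; beyond the scatter), so the higher number of compound 2 is not kept with this entering group. Going by these compounds alone, the other new step, a 1.0-fold lower number from compound 1 to compound 4 (0.00 log units; within the scatter), lies within the scatter, which shows for the first time that two different groups at this place, the one in compound 1 and the 2,5-dioxoimidazolidin-4-yl of compound 4, give matching numbers, with compound 2 apart from both. No measurement at hand accounts for this difference between the groups, and the numbers record only the size of the step.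

The step from compound 2 to compound 4 changes the ring methyl and the chain length together, so the compounds shown cannot assign the step to either; (2,5-dioxoimidazolidin-4-yl)methyl and 3-methyl-2,5-dioxoimidazolidin-4-yl on the same carbon would separate the two. Also open is how this carbon responds to a group outside this ring type, such as an amine or a carboxylic acid, since every group shown here is a five-membered non-aromatic ring with 2 hetero atoms.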